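Trifluoromethylphenyl in Place of the Fluorophenyl on the Saturated Ring

The source may hold more compounds than are shown below. What is called first, only, known or untested is meant among the compounds shown, and "the series" means these compounds.

Compound 3 `COc1ccc(-n2nc(Sc3ccc(Cl)cc3)cc(CC[C@@H](C)NC(=O)[C@H]3CNCC[C@@H]3c3ccccc3F)c2=O)cc1` gives the highest number of the three measured in an assay on CHO cells for binding affinity to Melanocortin receptor 4 (Homo sapiens) (on this read-out lower numbers stand for stronger inhibition and higher numbers for weaker inhibition), at 13 nM. Compound 1 `COc1ccc(-n2nc(Sc3ccc(Cl)cc3)cc(CC[C@@H](C)NC(=O)[C@H]3CNCC[C@@H]3c3ccc(Cl)cc3)c2=O)cc1` gives 2.4 nM and compound 2 `COc1ccc(-n2nc(Sc3ccc(Cl)cc3)cc(CC[C@@H](C)NC(=O)[C@H]3CNCC[C@@H]3c3ccc(Cl)cc3Cl)c2=O)cc1` gives 3.2 nM, so both sit beyond the scatter below compound 3. Compound 4 `COc1ccc(-n2nc(Sc3ccc(Cl)cc3)cc(CC[C@@H](C)NC(=O)[C@H]3CNCC[C@@H]3c3ccc(C(F)(F)F)cc3)c2=O)cc1` differs from compound 3 by 4-(trifluoromethyl)phenyl in place of 2-fluorophenyl on a saturated ring carbon. The measured steps that bear on this change run the other way: a 5.4-fold higher number from compound 1 to compound 3 (0.73 log units; beyond the scatter) and a 4.1-fold higher number from compound 2 to compound 3 (0.61 log units; beyond the scatter), each a modest loss on arriving at the 2-fluorophenyl. Returning to a phenyl that carries a single 4-substituent, here 4-(trifluoromethyl)phenyl, is therefore expected to lower the number in this assay, with the step estimated as a 3.3-fold lower number from compound 3 to compound 4 (0.51 log units; beyond the scatter). Compound 4 is expected to give about 4 nM, within a range of 1.5 nM to 12 nM.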

Compound 4, half-maximal inhibitory concentration: 3.8 nM
The estimate for compound 4 lay 1.1-fold (0.02 log units) above the measured number, and the stated range covers the measured number.
By their numbers in this assay, from the lowest: compounds 1, 2 and 4 (each within the scatter of the next); then compound 3.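

In this assay the 4-(trifluoromethyl)phenyl gives a 3.4-fold lower number from compound 3 to compound 4 (0.53 log units; beyond the scatter) and so reverses the loss seen with the 2-fluorophenyl. Trifluoromethyl in place of chloro gives a 1.6-fold higher number from compound 1 to compound 4 (0.20 log units; within the scatter) and the swap from 2,4-dichlorophenyl gives a 1.2-fold higher number from compound 2 to compound 4 (0.07 log units; within the scatter) and both steps lie within the scatter, so this saturated ring carbon accepts all three of these substituted phenyls alike. No measurement at hand explains the difference between these groups.

The compounds shown do not separate the effect of fluoro itself from that of where it sits on the phenyl. On these data alone, how a phenyl carrying a methoxy group or an amine would read also remains open.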